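The source may report more compounds than this note shows. Statements on the series, on what has been measured and on what is new or still open speak of the compounds shown alone.

Notes on the series, all on the shared core. In a functional assay on Raji cells (Homo sapiens) for antiproliferative activity, read by MTT assay, with a stated time of 48 h (a lower number here means a stronger inhibitor, a higher number a weaker inhibitor), compound 1 `CN(C)CCn1c(N)c(-c2nc3ccccc3[nH]2)c2nc(C#N)c(C#N)nc21` gives 8320 nM and compound 3 `CN(C)CCn1c(N)c(-c2nc3ccccc3n2C)c2nc(C#N)c(C#N)nc21` gives 46500 nM. Compound 2 `CCCCn1c(N)c(-c2nc3ccccc3[nH]2)c2nc(C#N)c(C#N)nc21` gives > 50000 nM, which is a limit and not a number. Compound 3 therefore has the higher of the two actual numbers.

Compound 4 `CCN(CC)CCCCn1c(N)c(-c2nc3ccccc3n2C)c2nc(C#N)c(C#N)nc21` differs from compound 3 by 2-(diethylamino)ethyl in place of dimethylamino on a saturated chain carbon, two bonds along the chain from an aromatic nitrogen.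

Going by the values given here, two measured steps bear on this. The methyl on the aromatic nitrogen, which compound 4 retains, accounts for a 5.6-fold higher number from compound 1 to compound 3 (0.75 log units; beyond the scatter) and sets the starting level. Ethyl in place of dimethylamino at the same place gave an at least 6.0-fold higher number from compound 1 to compound 2 (0.77 log units; beyond the scatter), but the entering group in compound 4 still holds a nitrogen, so no further rise is expected from that step. Neither step covers the longer chain, so only a small move towards a lower number is expected in this assay. The expected change is a 1.9-fold lower number from compound 3 to compound 4 (0.27 log units; within the scatter). For compound 4 the estimated value is 25000 nM, with an expected range of 7000 nM to 60000 nM.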

Compound 4, half-maximal inhibitory concentration: 920 nM
Beside the measured number, compound 4's estimate is 27-fold (1.43 log units) above it; measured number below the stated range.
By their numbers in this assay, from the lowest: compound 4; then compound 1; then compound 3. At a limit, above all of these: compound 2.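

In this assay the saturated chain carbon two bonds along the chain from an aromatic nitrogen can carry a strong gain, since the change to 2-(diethylamino)ethyl gives a 51-fold lower number from compound 3 to compound 4 (1.70 log units; beyond the scatter) and so far exceeds the scatter. The earlier change at this place, to ethyl, ran the opposite way with an at least 6.0-fold higher number from compound 1 to compound 2 (0.77 log units; beyond the scatter) as its step, which rests on a limit, so the direction depends on the entering group, although that step was read with hydrogen on the aromatic nitrogen. The methyl on the aromatic nitrogen, which gave a 5.6-fold higher number from compound 1 to compound 3 (0.75 log units; beyond the scatter) as its step, does not hold compound 4 at a high number.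

Chain length and the change from dimethylamino to diethylamino arrive together here, and a 4-(dimethylamino)butyl chain on the same core would separate them. Nothing shown bears on the cause of the step.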